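Series notes: amino chain shortening on the shared core

The compounds below may be only part of what the source reports. "The series", "measured", "known", "first", "only" and "open" are said of these compounds alone.

Measured so far:
- compound 1 `CC(C)CNc1cc(Oc2ccc(NC(=O)Nc3cccc(C(F)(F)F)c3)cc2)ncn1`: 50 nM
- compound 2 `CNc1cc(Oc2ccc(NC(=O)Nc3cccc(C(C)(C)C)c3)cc2)ncn1`: 40 nM
- compound 3 `CNc1cc(Oc2ccc(NC(=O)Nc3cccc(C(C)(F)F)c3)cc2)ncn1`: 40 nM

In an assay on isolated protein for inhibition of serine/threonine-protein kinase TNNI3K (Homo sapiens) (on this read-out higher numbers stand for weaker inhibition and lower numbers for stronger inhibition), compound 1 gives 50 nM, the highest of the three numbers, yet compound 2 at 40 nM and compound 3 at 40 nM both sit within the scatter of it, so no order among the three can be read from these values.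

Compound 4 `CCNc1cc(Oc2ccc(NC(=O)Nc3cccc(C(F)(F)F)c3)cc2)ncn1` is the next member. Relative to compound 1 the change is methyl in place of isopropyl on a saturated chain carbon bound to a nitrogen on an aromatic ring; cut one bond further out it reads isobutylamino to ethylamino, on the carbon chain carried by the nitrogen on the aromatic ring.

Among the measured compounds shown here, only one measured step exists, and it lies elsewhere: no change at the digits printed from compound 2 to compound 3 (within the scatter), a swap on the aromatic carbon of the urea-bearing ring. For the measured compounds named here, no measured step touches the amino chain itself, so nothing bears directly on this change. The three values together show the shared core tolerating changes at its periphery without movement beyond the scatter.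

The expectation for this assay is therefore a step of a 1.2-fold higher number from compound 1 to compound 4 (0.08 log units; within the scatter), that is none beyond the scatter, in either direction. Compound 4 is estimated at 60 nM, with a range from 25 nM to 150 nM.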

Compound 4, half-maximal inhibitory concentration: 25 nM
Compound 4: the middle estimate sits 2.4-fold (0.38 log units) above what was measured; the measured number falls inside the stated range.
By their numbers in this assay, from the lowest: compounds 4, 2, 3 and 1 (each within the scatter of the next).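

In this assay the amino chain now has a measured step of its own: a 2.0-fold lower number from compound 1 to compound 4 (0.30 log units; within the scatter), for methyl in place of isopropyl on a saturated chain carbon bound to a nitrogen on an aromatic ring. Earlier compounds offered only a step on the aromatic carbon of the urea-bearing ring, whereas this result shows that going from isobutylamino to ethylamino, with trifluoromethyl kept, moves the number no further than the scatter, so this position accepts both chains in this assay. No supporting data bear on why the number stays within the scatter here.

The compounds shown leave open whether a free amino group, a cyclopropylamino group or a hydroxyethylamino chain would also stay within the scatter of compound 4. Compounds 2 and 3 carry methylamino but differ from compound 4 in a second place, so the effect of that chain alone remains unread.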